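This account rests on a few compounds, and the source may have more. Where it says the series, first, only, none or still open, it means among the compounds named here.

Measured so far in an assay on BaF3 cells with thrombopoietin receptor (Homo sapiens) as the target, read by a luciferase reporter; on this read-out higher numbers stand for larger maximal responses and lower numbers for smaller maximal responses:

Compound 1 `Cc1[nH]n(C)c(=O)c1/N=N/c1c(O)cc(S(=O)(=O)O)c2ccccc12` gives < 5% in this assay, which is a limit of the assay and not a number.
Compound 2 `Cc1[nH]n(-c2ccc(C(C)(C)C)cc2)c(=O)c1/N=N/c1c(O)cc(S(=O)(=O)O)c2ccccc12` gives 86% in this assay.

Among the measured compounds shown here, compound 2 thus stands as the only number in hand; the other value is a limit (the limit of < 5% in this assay, at which 1 of the 2 values shown sits). For the measured compounds named here, the one measured step is a number at least 81 percentage points higher from compound 1 to compound 2 (beyond the scatter), 4-(tert-butyl)phenyl in place of methyl on an aromatic nitrogen.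

Compound 3 `Cc1[nH]n(-c2cc(Cl)c(S(=O)(=O)O)cc2Cl)c(=O)c1/N=N/c1c(O)cc(S(=O)(=O)O)c2ccccc12` is the next member. Its change from compound 2 is a group of 12 heavy atoms (6 carbon, 3 oxygen, 1 sulfur, 2 chlorine; one six-membered aromatic ring of carbon only) in place of a group of 10 heavy atoms (10 carbon; one six-membered aromatic ring of carbon only), on an aromatic nitrogen. Going by the values given here, the step from compound 1 to compound 2 bears on it only in part: it shows that an aromatic ring on that nitrogen, against methyl, carries the whole measured response, but no measured pair compares one such ring with another. The entering group keeps the six-membered aromatic ring and brings a sulfonic acid and two chlorines. Compound 3 is therefore expected to keep a response of the same kind, with a step of a number 21 percentage points lower from compound 2 to compound 3 (beyond the scatter) that may fall somewhat but is not expected to collapse to the limit. Compound 3 is estimated at 65%, within 30% to 95%.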

Compound 3, largest response reached (reported as efficacy), in percent of the reference or control that the assay uses: < 5%
Compound 3: no number, only a limit (the forecaster's own chance of this, stated with the estimate: 15%); middle value at least 60 percentage points away from the limit.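

In this assay, an aromatic ring of carbon only on the aromatic nitrogen is not enough to keep the response: exchanging 4-(tert-butyl)phenyl for a ring bearing a sulfonic acid and two chlorines gives a number at least 81 percentage points lower from compound 2 to compound 3 (beyond the scatter). The value of compound 3, < 5%, is a limit of the assay and not a number. The step from compound 1 to compound 2 had tied the response to the presence of a ring at this position, whereas compound 3 shows that what the ring carries decides the outcome, and the series now has two members at the low end of the read-out: the limit of < 5% in this assay, at which 2 of the 3 values shown sit.

The step between compound 1 and compound 3 cannot be read, and since compound 3 brings in the sulfonic acid and the two chlorines together, the compounds shown do not tell which of these goes with the loss of response. Also open, on these data alone, is how a ring carrying only the two chlorines, only the sulfonic acid, or a carboxylic acid or an amine in place of the sulfonic acid would read out at this nitrogen.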